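Ring-nitrogen substituent: from compound 2 to compound 3

This account rests on a few compounds, and the source may have more. Where it says the series, first, only, none or still open, it means among the compounds named here.

Measured so far:
compound 1 `COc1ccccc1N1C(=O)/C(=C/c2ccc(OCc3ccc(C(=O)O)cc3)cc2)SC1=S`: 2000 nM
compound 2 `O=C(O)c1ccc(COc2ccc(/C=C3\SC(=S)N(c4ccc(I)cc4)C3=O)cc2)cc1`: 4300 nM

In an assay on isolated protein for inhibition of Apoptosis regulator Bcl-2 (Homo sapiens), read by fluorescence polarization (a lower number here means a stronger inhibitor, a higher number a weaker inhibitor), compound 2 stands at the highest of the two numbers; its nearest neighbour is compound 1, and the step of a 2.2-fold higher number from compound 1 to compound 2 (0.33 log units; beyond the scatter) is modest but beyond the scatter. Compound 3 `O=C(O)c1ccc(COc2ccc(/C=C3\SC(=S)N(Cc4ccc(F)cc4)C3=O)cc2)cc1` differs from compound 2 in one place: 4-fluorobenzyl in place of 4-iodophenyl on an amide-type nitrogen in a ring. Going by the values given here, the only measured step, a 2.2-fold higher number from compound 1 to compound 2 (0.33 log units; beyond the scatter), also sits on this ring nitrogen, but it exchanges one aryl group for another and says nothing about a benzyl group there. It shows that a change at this position moves the number only modestly, so the step from compound 2 to compound 3 in this assay is expected to be small, with no clear direction. Compound 3 is therefore expected to give about 4000 nM, within 1500 nM to 12000 nM, which means an expected step of a 1.1-fold lower number from compound 2 to compound 3 (0.03 log units; within the scatter).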

Compound 3, inhibition constant: > 10000 nM
Compound 3 gave a limit, no number; the forecaster's own chance of this, stated with the estimate: 5%; middle value at least 2.5-fold (0.39 log units) from the limit.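

In this assay compound 3 reads > 10000 nM, which is a limit of the assay and not a number. The ring nitrogen is less forgiving than the exchange of one aryl group for another suggested: 4-fluorobenzyl in place of 4-iodophenyl gives an at least 2.3-fold higher number from compound 2 to compound 3 (0.36 log units; beyond the scatter), and 4-fluorobenzyl in place of 2-methoxyphenyl gives an at least 5.0-fold higher number from compound 1 to compound 3 (0.69 log units; beyond the scatter), both beyond the scatter. Of the three groups shown on this nitrogen, the two phenyl groups give numbers and the one benzyl group gives only a limit, so the full size of both steps cannot be read: the limit of > 10000 nM in this assay, at which 1 of the 3 values shown sits.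

The change from 4-iodophenyl to 4-fluorobenzyl alters both the group's link to the nitrogen and its halogen, and the compounds shown do not separate the two. Going by these compounds, whether 4-fluorophenyl, 4-iodobenzyl or a longer chain such as phenethyl on this nitrogen gives a number remains open.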